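Ethylcarbamoyl for allyl on the pyrrolidine-bearing core

A few compounds are considered here, and "the series" means these few. Any claim that something is new, unique, unknown or untested is made for them only; others in the source may bear on it.

Measured compounds:
compound 1, `C=CC[C@@H]1CN[C@H](C(=O)N2CCC[C@H]2C#N)C1`, 38%
compound 2, `C[C@@H]1N[C@H](C(=O)N2CCC[C@H]2C#N)C[C@@H]1C(=O)N1CCOCC1`, 94%

Two compounds have been run in an assay on the whole organism (plasma, strain Sprague-Dawley) for inhibition of Dipeptidyl peptidase 4 (Rattus norvegicus), with a stated time of 6 h, at a dose of 1 mg/kg by the oral route; a higher number here means more inhibition at the dose given (going by the name of the read-out), a lower number less inhibition. Compound 1 gives 38% and sits lowest of the two numbers; compound 2 gives 94%, a number that stands well beyond the scatter above compound 1. The two differ in more than one place, so nothing about any single change can be read from that pair; it shows only that a much higher inhibition is reachable on this shared core.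

The step now to be judged leads from compound 1 to compound 3, `CCNC(=O)[C@@H]1CN[C@H](C(=O)N2CCC[C@H]2C#N)C1`. The change is ethylcarbamoyl in place of allyl on a saturated ring carbon. Among the compounds with values here, no measured pair isolates this change, so the expectation rests on the spread of the two numbers alone. With compound 2 as the only pointer to how high this core can reach in this assay, an upward step is expected, of moderate size and well short of compound 2, estimated as a number 17 percentage points higher from compound 1 to compound 3 (beyond the scatter). For compound 3 the estimated inhibition in this assay is 55%, with a range from 25% to 85%.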

Compound 3, a percentage reported as inhibition, in the whole organism at one dose (the size of the read-out at that dose, not a potency): 60%
For compound 3 the middle estimate is 5 percentage points below the measured one, and the stated range covers the measured number.
By their numbers in this assay, from the lowest: compound 1; then compound 3; then compound 2.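

In this assay, ethylcarbamoyl in place of allyl on a saturated ring carbon, two ring bonds from the ring nitrogen, gives a number 22 percentage points higher from compound 1 to compound 3 (beyond the scatter). Within the data shown here, this is the first step that isolates a single place, and it shows that this ring carbon can carry ethylcarbamoyl with inhibition at the dose given rising rather than being lost, a reading that rests on this one pair and on a read-out that records size at one dose and time, not potency. No measurement shown here bears on what lies behind the step, so it stands as an observation only.

Going by these compounds, it remains open whether the rise belongs to the carbonyl, the amide hydrogen or the ethyl group, a question that an unsubstituted carboxamide, a carboxylic acid, an amine or a longer chain on the amide nitrogen at this same ring carbon could help to separate. Also open, on these data alone, is whether the step reflects inhibition of the enzyme itself or how much compound reaches the plasma at the stated time.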